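Furan in place of fluorophenyl on an inactive series

The source may hold more compounds than are shown below. What is called first, only, known or untested is meant among the compounds shown, and "the series" means these compounds.

Of the compounds shown here, three built on one shared core have been tested in a functional assay on HL-60 cells (Homo sapiens), read by calcium flux; a higher number here means that more compound is needed for the effect, a lower number that less compound is needed. Compound 1 `COc1ccc(Cc2cc(-c3ccc(Cl)cc3)nn(CC(=O)Nc3ccc(Br)cc3)c2=O)cc1` gives only a limit of the assay, > 50000 nM. Compound 2 `Cc1cc(Cc2ccccc2)c(=O)n(CC(=O)Nc2ccc(F)cc2)n1` likewise shows only a limit, > 50000 nM. Compound 3 `Cc1cc(Cc2cccc(F)c2)c(=O)n(CC(=O)Nc2ccc(Br)cc2)n1` also reaches only a limit in this assay, > 50000 nM. Compound 3 therefore stands nowhere in particular: every value shown sits at the limit of > 50000 nM in this assay, at which 3 of the 3 values shown sit, and none of them is a number that can be ranked against another.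

Compound 4 `Cc1cc(Cc2ccoc2)c(=O)n(CC(=O)Nc2ccc(Br)cc2)n1` differs from compound 3 in one place: furan-3-yl in place of 3-fluorophenyl on a saturated chain carbon bound to an aromatic carbon. Within the data shown here, no measured pair differs in the same way, so the size of this step cannot be read from the measured compounds. Because compound 3 sits at the limit of > 50000 nM in this assay, at which 3 of the 3 values shown sit, the expected step that the limit leaves unreadable from compound 3 to compound 4 is none beyond the scatter, and compound 4 is expected to give only a limit as well. The estimate for compound 4 in this assay is 80000 nM, with a range from 30000 nM to 300000 nM.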

Compound 4, half-maximal effective concentration: > 50000 nM
Compound 4: only a limit was reported (the forecaster's own chance of this, stated with the estimate: 85%); the middle value does not contradict the limit.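

Among these compounds, no step from compound 3 to compound 4 can be read, because both compounds give only a limit of the assay, not a number: the limit of > 50000 nM in this assay, at which 4 of the 4 values shown sit.

In this assay the compounds shown leave open whether furan-3-yl and 3-fluorophenyl differ at all, and whether any compound on this shared core gives a readable value.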